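From Phenylcarbamoyl to its Sulfur Counterpart: Cytotoxicity Outlook

The source may report more compounds than this note shows. Statements on the series, on what has been measured and on what is new or still open speak of the compounds shown alone.

Of the compounds shown here, two have so far been tested in an ADME assay on Vero cells (Chlorocebus sabaeus) for cytotoxicity, read by resazurin assay, with a stated time of 2 days; on this read-out lower numbers stand for higher toxicity in this test and higher numbers for lower toxicity in this test. Compound 1 `Cc1ccc(S(=O)(=O)Nc2cccc(/C=C/C(=O)C[C@@H]3OC[C@@H](O)[C@H](O)[C@H]3O)c2)cc1` gives 94700 nM, and compound 2 `CC(=O)OC[C@H]1O[C@@H](CC(=O)/C=C/c2cccc(NC(=O)Nc3ccccc3)c2)[C@@H](OC(C)=O)[C@@H](OC(C)=O)[C@@H]1OC(C)=O` gives 102000 nM; the two numbers lie within the usual scatter of one another. Compound 3 `CC(=O)OC[C@H]1O[C@@H](CC(=O)/C=C/c2cccc(NC(=S)Nc3ccccc3)c2)[C@@H](OC(C)=O)[C@@H](OC(C)=O)[C@@H]1OC(C)=O` follows from compound 2 by one change: a group of 9 heavy atoms (7 carbon, 1 nitrogen, 1 sulfur; one six-membered aromatic ring of carbon only) in place of a group of 9 heavy atoms (7 carbon, 1 nitrogen, 1 oxygen; one six-membered aromatic ring of carbon only), on a nitrogen on an aromatic ring. Going by the values given here, no measured pair shows what this swap does here, so the outlook rests on the close readings of compound 1 and compound 2. Compound 3 is expected to stay in the same region, with an estimated 90000 nM and a range from 40000 nM to 200000 nM. The implied step, a 1.1-fold lower number from compound 2 to compound 3 (0.05 log units; within the scatter), is expected to fall within the scatter.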

Compound 3, half-maximal cytotoxic concentration: 65100 nM
Compound 3: middle estimate off by 1.4-fold (0.14 log units), on the high side; low and high end bracket the measured number.
By their numbers in this assay, from the lowest: compounds 3, 1 and 2 (each within the scatter of the next).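

In this assay, going by these compounds alone, the first measured swap at this position, sulfur for oxygen in the phenylcarbamoyl group, gives a 1.6-fold lower number from compound 2 to compound 3 (0.20 log units; within the scatter). On a nitrogen on an aromatic ring, then, this exchange of one atom leaves the reading within what repeat measurements would show. No available measurement bears on the reason for this small step. Still open, as far as these compounds go, is whether a more different group on this nitrogen, such as an acetyl group or a chain carrying a carboxylic acid, would move the reading beyond the scatter.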